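The source may report more compounds than this note shows. Statements on the series, on what has been measured and on what is new or still open speak of the compounds shown alone.

Measured so far:
compound 1, `COc1cc2cc(Oc3ccc(NC(=O)Nc4cccc(C(F)(F)F)c4)cc3)c(C)nc2cc1OC`: 3590 nM
compound 2, `COc1cc2cc(Oc3ccc(NC(=O)Nc4ccc(Cl)c(C(F)(F)F)c4)cc3)c(C)nc2cc1OC`: 2910 nM

In a functional assay on SF-295 cells (Homo sapiens) for inhibition, read by sulforhodamine B assay, with a stated time of 48 h (a higher number here means a weaker inhibitor of growth, a lower number a stronger inhibitor of growth), compound 2 gives 2910 nM, and compound 1 gives 3590 nM; the step of a 1.2-fold lower number from compound 1 to compound 2 (0.09 log units; within the scatter) lies within the scatter, so the two compounds cannot be told apart. Compound 3, `COc1cc2cc(Oc3ccc(NC(=O)Nc4ccc(Cl)c(Cl)c4)cc3)c(C)nc2cc1OC`, differs from compound 2 by chloro in place of trifluoromethyl on an aromatic carbon. For the measured compounds named here, no measured step swaps these two groups; the only step known, a 1.2-fold lower number from compound 1 to compound 2 (0.09 log units; within the scatter), altered a different position and stayed within the scatter. The step of a 1.0-fold higher number from compound 2 to compound 3 (0.01 log units; within the scatter) is therefore expected to stay within the scatter as well. The estimate for compound 3 in this assay is 3000 nM, ranging from 1500 nM to 6000 nM.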

Compound 3, concentration for total growth inhibition: 6080 nM
Compound 3: middle estimate off by 2.0-fold (0.31 log units), on the low side; measured number outside the range, above it.
By their numbers in this assay, from the lowest: compounds 2, 1 and 3 (each within the scatter of the next, the first and the last beyond it).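

In this assay, for the compounds shown here, the change at this position is the first step here to pass the scatter: a 2.1-fold higher number from compound 2 to compound 3 (0.32 log units; beyond the scatter) shows that chloro in place of trifluoromethyl can shift the number, though only modestly. The wider change from 3-(trifluoromethyl)phenyl to 3,4-dichlorophenyl, a 1.7-fold higher number from compound 1 to compound 3 (0.23 log units; within the scatter) and stays within the scatter, so those two compounds cannot be told apart.

From the compounds shown here alone, how a nitrile or an amine on this aromatic carbon would compare remains open. Nothing available explains why the two groups differ.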